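This account rests on a few compounds, and the source may have more. Where it says the series, first, only, none or still open, it means among the compounds named here.

Compound 1 is `O=C(/C=C/c1ccc(OCCCCCO[N+](=O)[O-])c(O)c1)OCCCCCO[N+](=O)[O-]`; in a functional assay on HOP-62 cells (Homo sapiens) for cytotoxicity, read by resazurin assay, with a stated time of 72 h (a higher number here means a weaker inhibitor, a lower number a stronger inhibitor), compound 1 gives > 50000 nM, a limit of the assay rather than a number.
Compound 2 is `O=C(/C=C/c1ccc(OCCCCCCO[N+](=O)[O-])c(O)c1)OCCCCCCO[N+](=O)[O-]`; in this assay compound 2 gives > 50000 nM, also a limit.
Compound 3 is `COc1cc(/C=C/C(=O)OCCCCCO[N+](=O)[O-])ccc1OCCCCCO[N+](=O)[O-]`; in this assay compound 3 gives > 50000 nM, again a limit.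

The change from compound 1 to compound 3 is methyl in place of hydrogen on an oxygen on an aromatic ring. Its step, a step that the two limits leave unreadable from compound 1 to compound 3, cannot be sized because the limit of > 50000 nM in this assay, at which 3 of the 3 values shown sit, covers every value shown. How the core of compound 2 differs from the core of compound 1 is not broken down here.

Compound 4, `COc1cc(/C=C/C(=O)OCCCCCCO[N+](=O)[O-])ccc1OCCCCCCO[N+](=O)[O-]`, has not been measured. It differs from compound 2 by methyl in place of hydrogen on an oxygen on an aromatic ring, the same change as from compound 1 to compound 3, at a place described in the same words.

The step from compound 2 to compound 4 in this assay is expected to be a step that the limit leaves unreadable from compound 2 to compound 4, resting on compound 2 sitting at > 50000 nM and on the matching change leaving compound 3 at a limit too. Compound 4 is therefore expected to give about 70000 nM, most likely reported only as a limit, within 30000 nM to 200000 nM.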

Compound 4, half-maximal inhibitory concentration: > 50000 nM
Compound 4 was reported as a limit; the forecaster's own chance of this, stated with the estimate: 85%; the middle value is on the limit's open side.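

The step from compound 2 to compound 4, hydroxy to methoxy, cannot be sized, because neither compound has a measured number, only a limit: the limit of > 50000 nM in this assay, at which 4 of the 4 values shown sit.

The compounds shown leave open what concentration, if any, would inhibit these cells, and how hydroxy to methoxy would change a value that can be read in this assay.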